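Cyclobutyl in place of the aryl amide on the shared core

The source may hold more compounds than are shown below. What is called first, only, known or untested is meant among the compounds shown, and "the series" means these compounds.

In an in vitro functional assay on HEK293-A cells for antagonist activity at metabotropic glutamate receptor 5 (Rattus norvegicus), read by calcium flux (on this read-out lower numbers stand for stronger inhibition and higher numbers for weaker inhibition), the series rests on one core carrying two amides. Compound 1 `COc1ccccc1C(=O)Nc1cccc(NC(=O)c2ccc(Cl)cc2)c1` gives only a limit of the assay, > 30000 nM. Compound 2 `COc1ccccc1C(=O)Nc1cccc(NC(=O)c2ccc(Cl)c(Cl)c2)c1` likewise gives only a limit, > 30000 nM. Compound 1 and compound 2 both sit at the limit of > 30000 nM in this assay, at which 2 of the 3 values shown sit. Within the data shown here, compound 3 `COc1ccccc1C(=O)Nc1cccc(NC(=O)c2cccc(C#N)c2)c1` gives 1800 nM, the only number among the three values shown. The step from compound 1 to compound 2 reads a step that the two limits leave unreadable from compound 1 to compound 2. The two steps into compound 3 read an at least 16-fold lower number from compound 1 to compound 3 (1.22 log units; beyond the scatter) and an at least 16-fold lower number from compound 2 to compound 3 (1.22 log units; beyond the scatter); each exchanges the group on the carbonyl carbon.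

Compound 4 `COc1ccccc1C(=O)Nc1cccc(NC(=O)C2CCC2)c1` is not yet measured. It differs from compound 3 by cyclobutyl in place of 3-cyanophenyl on a carbonyl carbon. The measured steps that bear on this place are an at least 16-fold lower number from compound 1 to compound 3 (1.22 log units; beyond the scatter) and an at least 16-fold lower number from compound 2 to compound 3 (1.22 log units; beyond the scatter), both swaps of one aromatic group for another at the same carbonyl carbon. Among the measured compounds shown here, no measured step removes the aromatic ring, so the expectation rests on two of three groups at this position sitting at the limit, with 3-cyanophenyl alone giving a number. The expected step from compound 3 to compound 4 in this assay is an 8.3-fold higher number from compound 3 to compound 4 (0.92 log units; beyond the scatter), toward a higher number. Compound 4 is estimated at 15000 nM, between 3000 nM and 40000 nM, with a real chance that only a limit is reported.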

Compound 4, half-maximal inhibitory concentration: > 30000 nM
Compound 4: a limit, no number; the forecaster's own chance of this, stated with the estimate: 50%; middle value at least 2.0-fold (0.30 log units) from the limit.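

In this assay, cyclobutyl in place of 3-cyanophenyl on the carbonyl carbon gives an at least 16-fold higher number from compound 3 to compound 4 (1.22 log units; beyond the scatter), the only readable step shown that removes the aromatic ring from this place rather than exchanging one aromatic group for another. Among the four groups shown here, only 3-cyanophenyl gives a number, while cyclobutyl, 4-chlorophenyl and 3,4-dichlorophenyl all end at the same limit of the assay: the limit of > 30000 nM in this assay, at which 3 of the 4 values shown sit. The steps from compound 1 and from compound 2 to compound 4 join two limits and cannot be read, so cyclobutyl cannot be ranked against either chlorinated phenyl group.

As far as these compounds go, it remains open whether the number for compound 3 depends on the nitrile or on the phenyl ring that carries it, a question that unsubstituted phenyl or a methoxyphenyl group on the same carbonyl carbon would address. From the compounds shown here alone, it is also open whether a larger non-aromatic ring such as cyclohexyl, or a pyridine ring, would return a number at this place.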